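A Methoxy Added to a Compound at the Limit

The source may hold more compounds than are shown below. What is called first, only, known or untested is meant among the compounds shown, and "the series" means these compounds.

Compound 1 `Cc1nc(SCC(=O)Nc2nc(-c3ccc(Cl)cc3)cs2)n(Nc2ccccc2)c1C` is assessed in a functional assay on SF-295 cells (Homo sapiens) for antiproliferative activity, read by sulforhodamine B assay, with a stated time of 48 h; a lower number here means that less compound is tolerated, a higher number that more compound is tolerated. In this assay compound 1 reaches only the limit of > 100000 nM, which is a boundary of the measurement rather than a number. Compound 2 `Cc1ccc(Nn2c(SCC(=O)Nc3nc(-c4ccccc4)cs3)nc(C)c2C)cc1` shares the same core but differs in its outer groups. In this assay compound 2 likewise stops at the limit of > 100000 nM. For the measured compounds named here, both recorded values sit at the limit of > 100000 nM in this assay, at which 2 of the 2 values shown sit, so no measured step between two compounds is available, and compound 1 stands together with the only other value at that same boundary.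

Compound 3 `COc1ccc(Nn2c(SCC(=O)Nc3nc(-c4ccc(Cl)cc4)cs3)nc(C)c2C)cc1` is not yet measured. It differs from compound 1 by methoxy in place of hydrogen on an aromatic carbon. With both measured values resting at this boundary, no measured change of this kind exists for comparison. The expectation is that the step of a number no higher from compound 1 to compound 3 (the limit leaves the size open) stays within the scatter rather than moving in either direction. Compound 3 is therefore estimated at 100000 nM, with a range from 30000 nM to 300000 nM, and most likely it will again be reported only as a limit.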

Compound 3, concentration lethal to 50% of the cells: > 100000 nM
Compound 3: a limit, no number; the forecaster's own chance of this, stated with the estimate: 75%; the middle value sits exactly at the limit.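

In this assay compound 3 gives > 100000 nM as a limit and not a number. The change from compound 1 to compound 3 therefore cannot be read, because all the values rest at one boundary: the limit of > 100000 nM in this assay, at which 3 of the 3 values shown sit. The compounds shown leave open how methoxy in place of hydrogen acts on a compound whose value is a readable number.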